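Methyl on the benzoyl ring: third substituent pair in series

The source may hold more compounds than are shown below. What is called first, only, known or untested is meant among the compounds shown, and "the series" means these compounds.

Three compounds of the series carry a measurement in an ADME assay on C8166 cells (Homo sapiens) for cytotoxicity, read by colorimetric assay and MTT assay; on this read-out higher numbers stand for lower toxicity in this test and lower numbers for higher toxicity in this test. Compound 1 `Cc1cc(S(N)(=O)=O)ccc1NC(=O)COc1ccc2ccccc2c1C(=O)c1ccccc1` gives 33800 nM. Compound 2 `Cc1cccc(C(=O)c2c(OCC(=O)Nc3ccc(S(N)(=O)=O)cc3C)ccc3ccccc23)c1` gives 40400 nM. Compound 3 `Cc1cc(S(N)(=O)=O)ccc1NC(=O)COc1ccc2cc(Br)ccc2c1C(=O)c1ccccc1` gives 29200 nM, the lowest of the three numbers, though its gap to compound 1 and to compound 2 stays within the scatter, so no order among the three can be claimed.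

Compound 4 `Cc1cccc(C(=O)c2c(OCC(=O)Nc3ccc(S(N)(=O)=O)cc3C)ccc3cc(Br)ccc23)c1` has not been measured. It differs from compound 3 by methyl in place of hydrogen on an aromatic carbon.

For the measured compounds named here, one measured step bears directly on this change: a 1.2-fold higher number from compound 1 to compound 2 (0.08 log units; within the scatter), the same methyl entering the same ring on the core without the bromo. The other measured step, a 1.2-fold lower number from compound 1 to compound 3 (0.06 log units; within the scatter), concerns the bromo and only fixes where compound 3 starts. Neither step leaves the scatter. For this assay the expected step is therefore a 1.2-fold higher number from compound 3 to compound 4 (0.07 log units; within the scatter), none beyond the scatter in either direction.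

On that basis compound 4 is estimated at 34000 nM, with a range from 20000 nM to 58000 nM.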

Compound 4, half-maximal cytotoxic concentration: 6800 nM
For compound 4 the middle estimate is 5.0-fold (0.70 log units) above the measured one, and the stated range ends above it.
By their numbers in this assay, from the lowest: compound 4; then compounds 3, 1 and 2 (each within the scatter of the next).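

In this assay, for the compounds shown here, the change from phenyl to 3-methylphenyl is not neutral on every core, as the earlier compounds alone suggested: on the bromo core it gives a 4.3-fold lower number from compound 3 to compound 4 (0.63 log units; beyond the scatter), so the effect of this methyl depends on the core that carries it: the same change on two cores in this assay, a 1.2-fold higher number (0.08 log units; within the scatter) from compound 1 to compound 2 and a 4.3-fold lower number (0.63 log units; beyond the scatter) from compound 3 to compound 4, 5.1-fold (0.71 log units) apart, beyond the scatter of two such steps. Read from the other side, bromo in place of hydrogen gives a 5.9-fold lower number from compound 2 to compound 4 (0.77 log units; beyond the scatter), and its effect likewise depends on whether the methyl is present: the same change on two cores in this assay, a 1.2-fold lower number (0.06 log units; within the scatter) from compound 1 to compound 3 and a 5.9-fold lower number (0.77 log units; beyond the scatter) from compound 2 to compound 4, 5.1-fold (0.71 log units) apart, beyond the scatter of two such steps. The two changes therefore do not simply add, and the lower number, which stands for higher toxicity in this test, appears among these four compounds only where methyl and bromo occur together.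

The compounds shown leave open whether this shift belongs to methyl itself or would also follow from an ethyl or a methoxy group on the same ring carbon of the bromo core. They also leave open whether bromo is needed as such, or whether a chloro group or a nitrile in its place would pair with the methyl in the same way.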